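The source may hold more compounds than are shown below. What is called first, only, known or untested is meant among the compounds shown, and "the series" means these compounds.

Measured in an assay on isolated protein for inhibition of Fatty-acid amide hydrolase 1 (Homo sapiens), read by fluorescence, with a stated time of 30 min; a higher number here means a weaker inhibitor, a lower number a stronger inhibitor:

compound 1, `CCOC(=O)c1cc(-c2cccc(OC(=O)NC3CCCCC3)c2)nn1C`: 227 nM
compound 2, `CCOC(=O)c1cc(-c2cccc(OC(=O)NC3CCCCC3)c2)nn1-c1ccccc1`: 539 nM
compound 3, `CCOC(=O)c1cc(-c2ccc(OC(=O)NC3CCCCC3)cc2)nn1C`: 316 nM

Compound 4, `CCOC(=O)c1cc(-c2ccc(OC(=O)NC3CCCCC3)cc2)nn1-c1ccccc1`, has no value yet in this assay. It stands to compound 3 as compound 2 stands to compound 1: the change is phenyl in place of methyl on an aromatic nitrogen, and the same change, at the same place, is phenyl in place of methyl on an aromatic nitrogen. The difference between the core of compound 1 and the core of compound 3 is not broken down here; the two share the same atoms, joined differently. In this assay compound 3 sits within the scatter of compound 1, and also within the scatter of compound 2, so no order among these three can be read from their numbers alone.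

Among the measured compounds shown here, the one measured instance of the change gave a 2.4-fold higher number from compound 1 to compound 2 (0.38 log units; beyond the scatter), a modest step that is beyond the scatter. For the measured compounds named here, with only this one pair to go on, the expectation for compound 4 rests on carrying that step over to compound 3, whose value is 316 nM. The step from compound 3 to compound 4 is therefore estimated as a 2.4-fold higher number from compound 3 to compound 4 (0.38 log units; beyond the scatter), with wider uncertainty than the measured pair shows, since the two cores are not the same and nothing says the change transfers unchanged. Compound 4 is expected to give about 750 nM in this assay, most likely between 350 nM and 1600 nM.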

Compound 4, half-maximal inhibitory concentration: 592 nM
Compound 4: middle estimate off by 1.3-fold (0.10 log units), on the high side; low and high end bracket the measured number.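

In this assay, phenyl in place of methyl on the aromatic nitrogen gives a 1.9-fold higher number from compound 3 to compound 4 (0.27 log units; within the scatter), so on this core the step alone does not separate the two compounds, whereas on the other core it gives a 2.4-fold higher number from compound 1 to compound 2 (0.38 log units; beyond the scatter). Set side by side, the two steps do not differ: the same change on two cores in this assay, a 2.4-fold higher number (0.38 log units; beyond the scatter) from compound 1 to compound 2 and a 1.9-fold higher number (0.27 log units; within the scatter) from compound 3 to compound 4, 1.3-fold (0.10 log units) apart, within the scatter of two such steps This supports treating the change as a step of similar size on these two cores, but it rests on only two pairs, says nothing about any other core, and gives no reason for the size of the step.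

The compounds shown carry only methyl or phenyl on the aromatic nitrogen, which leaves open where a longer chain such as butyl, or a benzyl group, would fall in this assay. Every compound shown also keeps the ethoxycarbonyl group, so it remains open whether the phenyl-for-methyl step would stay of similar size with a carboxylic acid or a primary amide at that ring atom.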